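Acetyl capping of the free amine on the shared core

The source may report more compounds than this note shows. Statements on the series, on what has been measured and on what is new or still open speak of the compounds shown alone.

Of the compounds shown here, two have been measured in a toxicity assay on HepG2 cells (Homo sapiens) for cytotoxicity, read by MTT assay, with a stated time of 24 h; a lower number here means that less compound is tolerated, a higher number that more compound is tolerated. Compound 1, `Brc1ccc(Nc2nc3ccccc3nc2Nc2ccc(Br)cc2)cc1`, gives 7120 nM in this assay. Compound 2, `Nc1ccc2nc(Nc3ccc(Cl)c(Cl)c3)c(Nc3ccc(Cl)c(Cl)c3)nc2c1`, gives 25100 nM in this assay, the higher of the two numbers; its gap to compound 1 lies beyond the scatter, so compound 2 is the better tolerated of the pair on these data.

Compound 3, `CC(=O)Nc1ccc2nc(Nc3ccc(Cl)c(Cl)c3)c(Nc3ccc(Cl)c(Cl)c3)nc2c1`, has not yet been measured in this assay. It differs from compound 2 in one place: acetyl in place of hydrogen on a nitrogen on an aromatic ring. Among the compounds with values here, no comparable single-point step has been measured, so nothing here shows how this assay answers such a change.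

The expectation for compound 3 is therefore anchored on compound 2 and kept close to it: the step from compound 2 to compound 3 is estimated at a 1.3-fold lower number from compound 2 to compound 3 (0.10 log units; within the scatter), a change not clearly beyond the scatter in either direction. Compound 3 is estimated at 20000 nM in this assay, with a range from 8000 nM to 50000 nM reflecting the absence of any measured step of this kind.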

Compound 3, half-maximal cytotoxic concentration: 8600 nM
Estimate against measurement, compound 3: 2.3-fold (0.37 log units) above, and the stated range covers the measured number.
By their numbers in this assay, from the lowest: compounds 1 and 3 (each within the scatter of the next); then compound 2.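

Working notes: in this assay, acetyl in place of hydrogen on this nitrogen gives the first single-place step in the series (a 2.9-fold lower number from compound 2 to compound 3 (0.47 log units; beyond the scatter)), which lies beyond the scatter and is modest in size, so amino to acetamido at this position is a change the assay registers, and the free amine of compound 2 is the better tolerated of the pair. The earlier compounds shown here could not show this, since compound 1 and compound 2 differ in more than one place and left the response at this nitrogen unknown. Nothing available accounts for the direction of this step, so the pair records the change without explaining it.

Still open, on these data alone, is whether the lower number belongs to acetyl specifically or to capping of this nitrogen in general, a question that a longer acyl chain such as propionyl, a methyl group on the nitrogen or a methanesulfonyl group would address. Within the data shown here, also open is whether a carboxylic acid or a basic dimethylamino chain attached at this nitrogen would keep the number near that of compound 2 or move it further, since one pair fixes only one direction for one group.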